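The source may hold more compounds than are shown below. What is called first, only, known or untested is meant among the compounds shown, and "the series" means these compounds.

Working notes on the series. Going by the values given here, compound 1 `CCCN(CCC)c1nc(C(F)(F)F)ccc1CNC(=O)C(C)c1ccc(NS(C)(=O)=O)c(F)c1` is the reference point: in a functional assay on CHO-K1 cells for antagonist activity at transient receptor potential cation channel subfamily V member 1 (Homo sapiens), read by FLIPR (a lower number here means a stronger inhibitor, a higher number a weaker inhibitor), compound 1 gives 14.7 nM, the only number in hand for this set. Compound 2 `C[C@H](C(=O)NCc1ccc(C(F)(F)F)nc1N1CCC[C@H]1C(=O)N(C)C)c1ccc(NS(C)(=O)=O)c(F)c1` carries a different substituent at the same position of the shared core; in this assay compound 2 is reported as "not active" (no number reported), with no number given, so compound 1 stands alone as the measured anchor.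

Compound 3 `CC(C(=O)NCc1ccc(C(F)(F)F)nc1N1CCC(CN(C)C)CC1)c1ccc(NS(C)(=O)=O)c(F)c1` keeps the rest of compound 1 and alters a single site: 4-((dimethylamino)methyl)piperidin-1-yl in place of dipropylamino on an aromatic carbon. Among the compounds with values here, no step between two measured compounds is available for this kind of change, so the expectation rests on compound 1 alone and on the outcome for compound 2. The step from compound 1 to compound 3 in this assay is expected to be a 6.8-fold higher number from compound 1 to compound 3 (0.83 log units; beyond the scatter), a loss beyond the usual scatter rather than a neutral swap. Compound 3 is accordingly estimated at 100 nM, with a range from 20 nM to 800 nM.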

Compound 3, half-maximal inhibitory concentration: 426 nM
Compound 3: the middle estimate sits 4.3-fold (0.63 log units) below what was measured; the range from low to high includes it.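

In this assay the exchange of dipropylamino for 4-((dimethylamino)methyl)piperidin-1-yl on this aromatic carbon produces a 29-fold higher number from compound 1 to compound 3 (1.46 log units; beyond the scatter) and so marks the position as sensitive to the group it carries. The change does not abolish activity, however: compound 3 still gives a measurable value, so a six-membered non-aromatic ring with a dimethylaminomethyl side chain is accepted here at a clear cost. Nothing in hand bears on what lies behind this loss.

The compounds shown leave open whether the ring or the dimethylaminomethyl side chain carries the loss, a question that an unsubstituted piperidin-1-yl or a morpholin-4-yl at the same carbon would address. Also open, from the compounds shown here alone, is how a shorter or longer open chain, such as diethylamino or dibutylamino, would compare with dipropylamino.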